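The compounds below may be only part of what the source reports. "The series", "measured", "known", "first", "only" and "open" are said of these compounds alone.

Among the compounds with values here, in an assay on RPMI-8866 cells for inhibition of integrin alpha-4/beta-1 (Homo sapiens) (a higher number here means a weaker inhibitor, a lower number a stronger inhibitor), compound 3 `O=C(O)C[C@@H](NC(=O)[C@@H]1CCCN1S(=O)(=O)c1cc(Cl)cc(Cl)c1)c1ccc(O)cc1` gives 0.74 nM, the lowest of the three numbers measured so far. Compound 1 `C/C=C/[C@@H](CC(=O)O)NC(=O)[C@@H]1CCCN1S(=O)(=O)c1cc(Cl)cc(Cl)c1` gives 13 nM, and compound 2 `O=C(O)CCNC(=O)[C@@H]1CCCN1S(=O)(=O)c1cc(Cl)cc(Cl)c1` gives 1510 nM. The steps between these three are all large: a 2000-fold lower number from compound 2 to compound 3 (3.31 log units; beyond the scatter), an 18-fold lower number from compound 1 to compound 3 (1.24 log units; beyond the scatter), and a 120-fold higher number from compound 1 to compound 2 (2.07 log units; beyond the scatter). Each of these steps exchanges the entire group on the saturated chain carbon bound to an amide-type nitrogen and a saturated chain carbon; none of them touches the hydroxy group of compound 3 itself.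

Compound 4 `CC(C)(C)Oc1ccc([C@@H](CC(=O)O)NC(=O)[C@@H]2CCCN2S(=O)(=O)c2cc(Cl)cc(Cl)c2)cc1` differs from compound 3 in exactly one place: tert-butyl in place of hydrogen on an oxygen on an aromatic ring. Within the data shown here, no measured step changes anything on that oxygen, so the three steps show only that the 4-hydroxyphenyl as a whole carries much of the strength of compound 3, not what the hydrogen on its oxygen contributes. Among the measured compounds shown here, with no direct precedent in this set, the expectation for compound 4 is a modest weakening that stays close to compound 3, expressed as a 4.1-fold higher number from compound 3 to compound 4 (0.61 log units; beyond the scatter). Compound 4 is therefore estimated at 3 nM in this assay, with a range from 0.5 nM to 20 nM.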

Compound 4, half-maximal inhibitory concentration: 0.53 nM
Estimate against measurement, compound 4: 5.7-fold (0.75 log units) above, within the range that was stated.
By their numbers in this assay, from the lowest: compounds 4 and 3 (each within the scatter of the next); then compound 1; then compound 2.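

In this assay the step of a 1.4-fold lower number from compound 3 to compound 4 (0.14 log units; within the scatter) shows that the hydrogen on the oxygen of the 4-hydroxyphenyl can give way to tert-butyl with no difference that these measurements can detect, so a free hydroxy group is not needed here for a low number. Within the data shown here, the earlier compounds showed only that the whole aryl group mattered, and 4-(tert-butoxy)phenyl now keeps that large advantage, with a 2800-fold lower number from compound 2 to compound 4 (3.45 log units; beyond the scatter) against hydrogen on the saturated chain carbon and a 25-fold lower number from compound 1 to compound 4 (1.39 log units; beyond the scatter) against prop-1-en-1-yl at the same carbon. No measurement at hand explains why this position accepts the change.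

On this oxygen the compounds shown carry only hydrogen and tert-butyl, so it stays open whether a small methyl group, a longer chain ending in an amine, or a chain ending in a carboxylic acid would also leave the number unchanged. Going by these compounds, it also stays open whether tert-butoxy would behave the same way on a compound that differs from compound 3 elsewhere in the shared core.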